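One More Methyl on the Core of Compound 1

The compounds below may be only part of what the source reports. "The series", "measured", "known", "first", "only" and "open" are said of these compounds alone.

The measured compounds are: compound 1 `CC(C)c1cc(Cn2ccc3cc(OCC(=O)O)ccc32)ccc1O`, 13.5 nM; compound 2 `Cc1cc2cc(OCC(=O)O)ccc2n1Cc1ccc(O)c(C(C)C)c1`, 16.3 nM; compound 3 `Cc1cn(Cc2ccc(O)c(C(C)C)c2)c2ccc(OCC(=O)O)cc12`, 7.74 nM.

In an assay on HeLa cells for displacement of a labelled ligand from thyroid hormone receptor alpha (Homo sapiens) (on this read-out lower numbers stand for stronger inhibition and higher numbers for weaker inhibition), compound 1 holds the second highest of the three numbers. The step of a 1.2-fold higher number from compound 1 to compound 2 (0.08 log units; within the scatter) and the step of a 1.7-fold lower number from compound 1 to compound 3 (0.24 log units; within the scatter) both stay within the scatter. Compound 4 `Cc1cc(OCC(=O)O)cc2ccn(Cc3ccc(O)c(C(C)C)c3)c12` differs from compound 1 by methyl in place of hydrogen on an aromatic carbon. The two measured steps also put a methyl in place of hydrogen on an aromatic carbon of the shared core, and neither moved the number beyond the scatter, so no step beyond the scatter is expected in this assay here either. Compound 4 is therefore estimated at 13 nM, between 6 nM and 30 nM, which amounts to an expected step of a 1.0-fold lower number from compound 1 to compound 4 (0.02 log units; within the scatter).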

Compound 4, inhibition constant: 1.09 nM
Compound 4: middle estimate off by 12-fold (1.08 log units), on the high side; measured number outside the range, below it.
By their numbers in this assay, from the lowest: compound 4; then compounds 3, 1 and 2 (each within the scatter of the next, the first and the last beyond it).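

In this assay, methyl on the aromatic carbon ortho to a fused ring and meta to a carboxymethoxy group gives a 12-fold lower number from compound 1 to compound 4 (1.09 log units; beyond the scatter) and is the only one of the three methyl steps from compound 1 beyond the scatter. The same replacement of hydrogen by methyl on the shared core therefore does not act alike at every place: only here, and not in compound 2 or compound 3, does it clearly lower the number. Nothing available explains why this position stands apart. The compounds shown leave open whether an ethyl or a methoxy group on this same aromatic carbon would keep the lower number.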